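Benzylamino Replaces Ethoxy: What to Expect for Compound 3

The source may report more compounds than this note shows. Statements on the series, on what has been measured and on what is new or still open speak of the compounds shown alone.

compound 1 `CCOC1=C(C(=O)c2ccccc2)C(c2ccc(Br)cc2)N(CCCn2ccnc2)C1=O`: 35300 nM
compound 2 `O=C(C1=C(Nc2ccc(Cl)cc2)C(=O)N(CCCn2ccnc2)C1c1ccc(Br)cc1)c1ccccc1`: 30000 nM

In a functional assay on A549 cells (Homo sapiens) for antiproliferative activity, read by MTT assay, with a stated time of 72 h (a higher number here means a weaker inhibitor, a lower number a stronger inhibitor), compound 1 stands highest of the two numbers; its nearest neighbour is compound 2, reached by a 1.2-fold lower number from compound 1 to compound 2 (0.07 log units; within the scatter). Compound 3 `O=C(C1=C(NCc2ccccc2)C(=O)N(CCCn2ccnc2)C1c1ccc(Br)cc1)c1ccccc1` differs from compound 1 by benzylamino in place of ethoxy on a double-bonded ring carbon. Going by the values given here, the one step that bears on this change is the one where (4-chlorophenyl)amino replaced ethoxy on the same double-bonded ring carbon, and that step, a 1.2-fold lower number from compound 1 to compound 2 (0.07 log units; within the scatter), stayed within the scatter. No movement beyond the scatter is therefore expected in this assay. Compound 3 is estimated at 30000 nM, between 12000 nM and 75000 nM, an expected step of a 1.2-fold lower number from compound 1 to compound 3 (0.07 log units; within the scatter).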

Compound 3, half-maximal inhibitory concentration: 52800 nM
Estimate against measurement, compound 3: 1.8-fold (0.25 log units) below; low and high end bracket the measured number.
By their numbers in this assay, from the lowest: compounds 2, 1 and 3 (each within the scatter of the next).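

In this assay benzylamino on the double-bonded ring carbon stays within the scatter of ethoxy (a 1.5-fold higher number from compound 1 to compound 3 (0.17 log units; within the scatter)). Benzyl in place of 4-chlorophenyl on the amine nitrogen also stays within it (a 1.8-fold higher number from compound 2 to compound 3 (0.25 log units; within the scatter)), so ethoxy, (4-chlorophenyl)amino and benzylamino cannot be told apart at this position in this assay. Nothing measured here offers an explanation for these numbers. The compounds shown leave open whether a primary amine, a carboxylic acid or a longer alkyl chain on this carbon would move the number beyond the scatter. They also leave open whether replacing the 4-bromophenyl or benzoyl group would do so.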